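The compounds below may be only part of what the source reports. "The series", "measured", "known", "first", "only" and "open" are said of these compounds alone.

Measured compounds:
compound 1, `Oc1cccc(-c2cc(-c3cccs3)cc(-c3ccccc3O)n2)c1`: > 50000 nM
compound 2, `Oc1cccc(-c2cc(-c3cccs3)cc(-c3cccc(O)c3)n2)c1`: 3480 nM

Both were run in a functional assay on HCT-15 cells (Homo sapiens) for cytotoxicity, read by CCK-8 assay; a higher number here means a weaker inhibitor, a lower number a stronger inhibitor. Compound 1 returns only an assay limit, > 50000 nM, not a number (the limit of > 50000 nM in this assay, at which 1 of the 2 values shown sits). For the measured compounds named here, compound 2, at 3480 nM, holds the only number in this assay. Going by the values given here, the single measured step, an at least 14-fold lower number from compound 1 to compound 2 (1.15 log units; beyond the scatter), is large.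

Compound 3, `Oc1ccc(-c2cc(-c3cccs3)cc(-c3cccc(O)c3)n2)cc1`, differs from compound 2 by 4-hydroxyphenyl in place of 3-hydroxyphenyl on an aromatic carbon. Among the compounds with values here, the only measured step bearing on this change is an at least 14-fold lower number from compound 1 to compound 2 (1.15 log units; beyond the scatter), which shows that the hydroxyl position on this ring shifts the number strongly. Within the data shown here, no measured pair covers 4-hydroxyphenyl itself, so the direction of this next shift is open; the expectation is therefore centred near compound 2 with a wide range. Expected step: a 1.1-fold higher number from compound 2 to compound 3 (0.06 log units; within the scatter). For compound 3 the estimate in this assay is 4000 nM, between 800 nM and 25000 nM.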

Compound 3, half-maximal inhibitory concentration: 1770 nM
The estimate for compound 3 lay 2.3-fold (0.35 log units) above the measured number, and the stated range covers the measured number.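

The change of 3-hydroxyphenyl to 4-hydroxyphenyl in this assay gives a 2.0-fold lower number from compound 2 to compound 3 (0.29 log units; within the scatter), so these two hydroxyl placements are not separated at this position. Against the 2-hydroxyphenyl compound the 4-hydroxyphenyl group gives an at least 28-fold lower number from compound 1 to compound 3 (1.45 log units; beyond the scatter), a second large step that makes compound 1 the one compound of the three set apart, where before a single pair could not show this. Compound 1 still stands at a limit of the assay, not a number: the limit of > 50000 nM in this assay, at which 1 of the 3 values shown sits.

As far as these compounds go, whether the hydroxyl is needed at all stays open, and a plain phenyl, a methoxy group or an amine on this ring would address that. From the compounds shown here alone, the remaining 3-hydroxyphenyl and thiophen-2-yl groups are constant across all three compounds, so their contribution to the numbers also stays open.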